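Swapping a dichlorophenyl for a dimethoxyphenyl on the ketone

The compounds below may be only part of what the source reports. "The series", "measured", "known", "first", "only" and "open" are said of these compounds alone.

Measured compounds:
compound 1 `COc1cc(-c2cc(/C=C/C(=O)c3ccc(Cl)c(Cl)c3)[nH]n2)cc(OC)c1OC`, 91%
compound 2 `COc1ccc(-c2cc(/C=C/C(=O)c3ccc(N)cc3)[nH]n2)cc1OC`, 93%

In a functional assay on SN12C cells (Homo sapiens) for cytotoxicity, read by sulforhodamine B assay, with a stated time of 48 h, tested at 1 uM (on this read-out higher numbers stand for a weaker effect at the one concentration tested and lower numbers for a stronger effect), compound 1 gives 91%. Compound 2 gives 93% in this assay, a result that lies within the scatter of compound 1, so the two cannot be told apart; compound 1 simply has the lower of the two numbers shown. Both are weak at the concentration tested.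

Compound 3 `COc1ccc(C(=O)/C=C/c2cc(-c3cc(OC)c(OC)c(OC)c3)n[nH]2)cc1OC` is not yet measured. It differs from compound 1 in one place: 3,4-dimethoxyphenyl in place of 3,4-dichlorophenyl on a carbonyl carbon. Going by the values given here, no pair of measured compounds shows what such a swap does here, and compound 2, which carries a different group on the carbonyl carbon, gives much the same number as compound 1.

Compound 3 is therefore expected to behave like its neighbours, with a step of a number 1 percentage points higher from compound 1 to compound 3 (within the scatter) that stays within the scatter. The estimate for compound 3 in this assay is 92%, between 80% and 102%.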

Compound 3, a percentage reported as activity, at one concentration (the size of the read-out at that concentration, not a potency): 80%
Compound 3: the middle estimate sits 12 percentage points above what was measured, within the range that was stated.
By their numbers in this assay, from the lowest: compound 3; then compounds 1 and 2 (each within the scatter of the next).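

The group on the carbonyl carbon can change the result: in this assay, replacing 3,4-dichlorophenyl with 3,4-dimethoxyphenyl gives a number 11 percentage points lower from compound 1 to compound 3 (beyond the scatter), a modest gain in effect and the first difference among these compounds to lie beyond the scatter. The entering group is larger by heavy atom count and carries hydrogen-bond acceptors where the leaving group has none. Nothing available explains the gain or ties it to either of these features.

Going by these compounds, how a plain phenyl on the carbonyl carbon would read remains open, and with it whether the gain comes from adding the methoxy groups or from losing the chlorines. On these data alone, compound 3 gives 80% at a single concentration, so its potency and how much further the effect could go also remain unknown.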